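Extending the chain by one carbon from compound 3 to compound 4

A few compounds are considered here, and "the series" means these few. Any claim that something is new, unique, unknown or untested is made for them only; others in the source may bear on it.

Three compounds were measured in a functional assay on HONE1 cells for cytotoxicity against HONE1 cell line (Homo sapiens); a lower number here means a stronger inhibitor, a higher number a weaker inhibitor. Compound 1 `N#C/N=C1\N(CCCCCOc2ccc(Cl)cc2)C(=O)CN1c1ccncc1` gave 3400 nM. Compound 2 `N#C/N=C1\N(CCCCCCOc2ccc(Cl)cc2)C(=O)CN1c1ccncc1` differs from it by (4-chlorophenoxy)methyl in place of 4-chlorophenoxy on a saturated chain carbon, five bonds along the chain from an amide-type nitrogen in a ring and gave 2960 nM, a step of a 1.1-fold lower number from compound 1 to compound 2 (0.06 log units; within the scatter). Compound 3 `CCC1C(=O)N(CCCCCCOc2ccc(Cl)cc2)/C(=N\C#N)N1c1ccncc1` gave 3870 nM, with a step of a 1.3-fold higher number from compound 2 to compound 3 (0.12 log units; within the scatter); how its core differs from that of compound 1 is not broken down here. Compound 4 `CCC1C(=O)N(CCCCCCCOc2ccc(Cl)cc2)/C(=N\C#N)N1c1ccncc1` is unmeasured and differs from compound 3 by (4-chlorophenoxy)methyl in place of 4-chlorophenoxy on a saturated chain carbon, six bonds along the chain from an amide-type nitrogen in a ring. This is the same kind of change as that between compound 1 and compound 2, but made six bonds rather than five bonds along the chain from an amide-type nitrogen in a ring. Since the earlier step was a 1.1-fold lower number from compound 1 to compound 2 (0.06 log units; within the scatter), the step is expected to be small, a 1.1-fold lower number from compound 3 to compound 4 (0.04 log units; within the scatter). Compound 4 is therefore estimated at 3500 nM, between 1800 nM and 7000 nM.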

Compound 4, half-maximal inhibitory concentration: 3230 nM
Beside the measured number, compound 4's estimate is 1.1-fold (0.03 log units) above it, within the range that was stated.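

In this assay, the (4-chlorophenoxy)methyl change gave a 1.2-fold lower number from compound 3 to compound 4 (0.08 log units; within the scatter), so on the ethyl-bearing core of compound 3 it again left the number within the scatter. Set beside the earlier step, the change carried from one core to the other with no detectable difference: the same change on two cores in this assay, a 1.1-fold lower number (0.06 log units; within the scatter) from compound 1 to compound 2 and a 1.2-fold lower number (0.08 log units; within the scatter) from compound 3 to compound 4, 1.0-fold (0.02 log units) apart, within the scatter of two such steps

This shows that the change did little on either core, but it does not show a real gain on either, and two steps this small cannot tell whether a larger effect would carry over. The compounds shown leave open whether a chain longer than that of compound 4 would move the number beyond the scatter. They also leave open what an amine or a carboxylic acid in place of the chlorine would do, on either core.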